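Removing a Methyl from Two Bitter Taste Receptor Antagonists

The compounds below may be only part of what the source reports. "The series", "measured", "known", "first", "only" and "open" are said of these compounds alone.

Compound 1 `COc1ccccc1C(=O)Nc1cnn(Cc2c(C)noc2C)c1` and compound 2 `Cc1noc(C)c1Cn1cc(NC(=O)c2ccccc2O)cn1` share one core. In a functional assay on cells for antagonist activity at taste receptor type 2 member 8 (Homo sapiens), read by FLIPR and calcium flux, with a stated time of 100 s (on this read-out lower numbers stand for stronger inhibition and higher numbers for weaker inhibition), compound 1 gives 1900 nM, while compound 2 gives 1000 nM. The change between them, (hydrogen in place of methyl on an oxygen on an aromatic ring), brought a 1.9-fold lower number from compound 1 to compound 2 (0.28 log units; within the scatter). Compound 3 `COc1ccccc1CN1CC(=O)N(c2cnn(Cc3c(C)noc3C)c2)C1=O` is built on another core, and the difference between the two cores is not broken down here. In this assay compound 3 gives 100 nM, the lowest of the three numbers and beyond the scatter from both compound 1 and compound 2.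

Compound 4 `Cc1noc(C)c1Cn1cc(N2C(=O)CN(Cc3ccccc3O)C2=O)cn1` has not yet been measured in this assay. It differs from compound 3 by hydrogen in place of methyl on an oxygen on an aromatic ring, the same change made from compound 1 to compound 2 and at the same kind of place. For the measured compounds named here, the only guide is that earlier pair, where the step was a 1.9-fold lower number from compound 1 to compound 2 (0.28 log units; within the scatter), so no large move is expected. Compound 4 is therefore expected to stand close to compound 3, with an estimated step of a 1.4-fold lower number from compound 3 to compound 4 (0.15 log units; within the scatter). Compound 4 is expected to give about 70 nM in this assay, with a likely range from 30 nM to 200 nM.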

Compound 4, half-maximal inhibitory concentration: 100 nM
Compound 4: middle estimate off by 1.4-fold (0.15 log units), on the low side, and the stated range covers the measured number.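

In this assay, moving from 2-methoxybenzyl to 2-hydroxybenzyl on the core of compound 3 gave no change at the digits printed from compound 3 to compound 4 (within the scatter). Set beside the same change on the core of compound 1, the two steps do not differ beyond what repeated measurements would give: the same change on two cores in this assay, a 1.9-fold lower number (0.28 log units; within the scatter) from compound 1 to compound 2 and no change at the digits printed (within the scatter) from compound 3 to compound 4, 1.9-fold (0.28 log units) apart, within the scatter of two such steps. For the compounds shown here, this shows that, on these two cores, hydrogen in place of methyl on an oxygen on an aromatic ring left the number within the scatter each time, so the pairs agree in showing no clear effect of the change; it does not show a rule for other cores, since it rests on only two pairs, neither with a step beyond the scatter.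

The compounds shown leave open whether an ethyl group or a longer chain on this oxygen, or an amine in place of the hydroxy, would read the same way on either core. They also leave open how the methoxy to hydroxy change would read on a third core.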